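The source may report more compounds than this note shows. Statements on the series, on what has been measured and on what is new or still open speak of the compounds shown alone.

Compound 1 `C/C(=C\CC/C(C)=C/CC[C@@H]1[C@@]2(C)CCC(=O)C(C)(C)[C@H]2CC[C@@]1(C)O)CC/C=C(\C)C(=O)OCc1cn(-c2cccc(O)c2)nn1` gives 42800 nM in a functional assay on A549 cells (Homo sapiens) for antiproliferative activity, read by MTT assay, with a stated time of 48 h; on this read-out higher numbers stand for weaker inhibition and lower numbers for stronger inhibition. Compound 2 `C/C(=C\CC/C(C)=C/CC[C@@H]1[C@@]2(C)CCC(=O)C(C)(C)[C@H]2CC[C@@]1(C)O)CC/C=C(\C)C(=O)OCc1cn(-c2ccccc2[N+](=O)[O-])nn1` reaches only the limit of > 150000 nM in this assay. Compound 3 `C/C(=C\CC/C(C)=C/CC[C@@H]1[C@@]2(C)CCC(=O)C(C)(C)[C@H]2CC[C@@]1(C)O)CC/C=C(\C)C(=O)OCc1cn(-c2ccc(C)cc2)nn1` likewise reaches only the limit of > 150000 nM in this assay, so where it stands is known only as a limit, a limit shared by one further value here (the limit of > 150000 nM in this assay, at which 2 of the 3 values shown sit). Compound 4 `C/C(=C\CC/C(C)=C/CC[C@@H]1[C@@]2(C)CCC(=O)C(C)(C)[C@H]2CC[C@@]1(C)O)CC/C=C(\C)C(=O)OCc1cn(-c2cccc([N+](=O)[O-])c2)nn1` differs from compound 3 by 3-nitrophenyl in place of 4-methylphenyl on an aromatic nitrogen. The measured steps that bear on this are an at least 3.5-fold higher number from compound 1 to compound 2 (0.54 log units; beyond the scatter) and an at least 3.5-fold higher number from compound 1 to compound 3 (0.54 log units; beyond the scatter), while the step that the two limits leave unreadable from compound 2 to compound 3 cannot be read. Compound 4 is therefore expected to stay at or near the limit, with an estimate of 150000 nM and a range from 60000 nM to 300000 nM. The step of a number no higher from compound 3 to compound 4 (the limit leaves the size open) is thus expected to stay within the scatter.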

Compound 4, half-maximal inhibitory concentration: > 150000 nM
Compound 4: a limit, no number (the forecaster's own chance of this, stated with the estimate: 65%); the middle value sits exactly at the limit.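

Compound 4 carries its group at the same ring position as compound 1, so this pair isolates the group itself: nitro in place of hydroxy gives an at least 3.5-fold higher number from compound 1 to compound 4 (0.54 log units; beyond the scatter). The value for compound 4 is a limit, not a number, and the 3-nitrophenyl group thus ends at the same limit as the 2-nitrophenyl and 4-methylphenyl groups: the limit of > 150000 nM in this assay, at which 3 of the 4 values shown sit. The steps among compounds 2, 3 and 4 therefore cannot be read.

On these data alone, whether an amine or a methoxy group at this ring position would match compound 1 stays open. So does the effect of moving the hydroxy group elsewhere on the ring.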